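Propargylamine coumarin ethers: methoxybenzyl for difluorobenzyl

The compounds below may be only part of what the source reports. "The series", "measured", "known", "first", "only" and "open" are said of these compounds alone.

Measured compounds in an ADME assay on isolated protein for inhibition of Amine oxidase [flavin-containing] A (Homo sapiens), read by fluorescence and Amplex Red, with stated times of 15 min and 20 min; a higher number here means a weaker inhibitor, a lower number a stronger inhibitor:
compound 1 `C#CCN(CCCCOc1ccc2ccc(=O)oc2c1)Cc1ccc(OC)cc1`: 54500 nM
compound 2 `C#CCN(CCCCOc1ccc2ccc(=O)oc2c1)Cc1cccc(OC)c1`: 78600 nM
compound 3 `C#CCN(CCCOc1ccc2ccc(=O)oc2c1)Cc1ccc(F)c(F)c1`: 49200 nM

All three numbers lie within the scatter of one another in this assay; compound 3 sits at the low end of that narrow band, with compound 1 nearest and compound 2 furthest.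

Compound 4 `C#CCN(CCCOc1ccc2ccc(=O)oc2c1)Cc1cccc(OC)c1` is obtained from compound 3 by the change (3-methoxyphenyl in place of 3,4-difluorophenyl on a saturated chain carbon bound to an amine nitrogen). Among the compounds with values here, no measured step covers this exchange directly. Within the data shown here, the only measured step, a 1.4-fold higher number from compound 1 to compound 2 (0.16 log units; within the scatter), moves the methoxy group around the ring on the longer chain and stays within the scatter, so methoxyphenyl variants on this core gave no shift. Among the measured compounds shown here, no pair among the measured compounds isolates the change from fluorine to methoxy or the chain length. The expected step of a 1.3-fold higher number from compound 3 to compound 4 (0.10 log units; within the scatter) is therefore within the scatter, with no direction beyond it. For compound 4 the estimate is 62000 nM with a range from 28000 nM to 140000 nM.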

Compound 4, half-maximal inhibitory concentration: 22700 nM
Compound 4: middle estimate off by 2.7-fold (0.44 log units), on the high side; the whole stated range lies above it.
By their numbers in this assay, from the lowest: compound 4; then compounds 3, 1 and 2 (each within the scatter of the next).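

On the saturated chain carbon bound to an amine nitrogen, 3-methoxyphenyl in place of 3,4-difluorophenyl moves the read-out beyond the scatter in this assay, with a 2.2-fold lower number from compound 3 to compound 4 (0.34 log units; beyond the scatter), so this exchange registers as a modest gain in inhibition. Within the data shown here, the only earlier step, a 1.4-fold higher number from compound 1 to compound 2 (0.16 log units; within the scatter), stayed within the scatter and showed no such movement at this ring. Nothing measured explains the step, and the added hydrogen-bond acceptor counted for 3-methoxyphenyl cannot be tied to it.

Going by these compounds, whether the gain belongs to the methoxy group or to the loss of the two fluorines stays open, and a 3-fluorophenyl or unsubstituted phenyl group on the same chain would separate the two. Also open, on these data alone, is whether the same exchange carries over to the longer chain of compound 1 and compound 2.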